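Swapping the aryl group at one place on the core

The compounds below may be only part of what the source reports. "The series", "measured", "known", "first", "only" and "open" are said of these compounds alone.

Values in an ADME assay on microsomes from liver (Rattus norvegicus) for metabolic stability, read by LC-MS, using NADPH, at 37 degrees C (on this read-out lower numbers stand for a shorter-lived compound and higher numbers for a longer-lived compound), are as follows.
Compound 1 `Cc1ccc(C)c(-c2nc(CN3CCC(C(=O)NCCCN4C[C@H](C)C[C@H](C)C4)CC3)c(C)o2)c1` gives 0.5 h
Compound 2 `Cc1oc(-c2ccc(F)cc2)nc1CN1CCC(C(=O)NCCCN2C[C@H](C)C[C@H](C)C2)CC1` gives 0.468 h

In this assay compound 2 stands at 0.468 h and compound 1 at 0.5 h and the two numbers lie within the scatter of each other. Compound 3 `Cc1oc(-c2c(Br)cccc2Br)nc1CN1CCC(C(=O)NCCCN2C[C@H](C)C[C@H](C)C2)CC1` differs from compound 2 by 2,6-dibromophenyl in place of 4-fluorophenyl on an aromatic carbon and so carries 2,6-dibromophenyl in place of 4-fluorophenyl on an aromatic carbon of a five-membered aromatic ring with 1 nitrogen and 1 oxygen. Among the compounds with values here, only one measured step bears on this change. At the same place, 4-fluorophenyl in place of 2,5-dimethylphenyl gave a 1.1-fold lower number from compound 1 to compound 2 (0.03 log units; within the scatter) and that step stays within the scatter. No measurement with 2,6-dibromophenyl exists, so this single step is a thin guide and the range must stay wide. No shift beyond the scatter is expected, and no direction is favoured. The estimated change is a 1.0-fold higher number from compound 2 to compound 3 (0.00 log units; within the scatter) in this assay for this swap. For compound 3 the expected half-life is 0.47 h (estimated range 0.22 h to 1 h).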

Compound 3, half-life: 0.035 h
Compound 3: the middle estimate sits 13-fold (1.13 log units) above what was measured, outside the stated range (below it).
By their numbers in this assay, from the lowest: compound 3; then compounds 2 and 1 (each within the scatter of the next).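

In this assay, the aryl place on the aromatic carbon of the five-membered ring had seemed indifferent to the swap between 2,5-dimethylphenyl and 4-fluorophenyl, but it proves able to shift the half-life strongly: 2,6-dibromophenyl in place of 4-fluorophenyl gives a 13-fold lower number from compound 2 to compound 3 (1.13 log units; beyond the scatter), and 2,6-dibromophenyl in place of 2,5-dimethylphenyl gives a 14-fold lower number from compound 1 to compound 3 (1.15 log units; beyond the scatter). Compound 1 and compound 2 lie within the scatter of each other. The two large steps agree, and among these three compounds the shortest half-life goes with the 2,6-dibromophenyl group alone. Nothing at hand explains why the half-life falls with this group.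

The compounds shown leave open whether the fall follows the bromine atoms themselves or the placing of two groups on the phenyl ring at the 2 and 6 positions. On these data alone, a 4-bromophenyl and a 2,6-dichlorophenyl group at this same place would pull those two readings apart, and how far either would move the half-life remains unknown.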